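A few compounds are considered here, and "the series" means these few. Any claim that something is new, unique, unknown or untested is made for them only; others in the source may bear on it.

Among the compounds with values here, in a functional assay on A549 cells (Homo sapiens) for cytotoxicity, read by MTT assay, with a stated time of 48 h (on this read-out lower numbers stand for stronger inhibition and higher numbers for weaker inhibition), only two compounds have numbers so far. Compound 1 (`COc1ccc(C2=NOC(COc3ccc(-c4nnnn4-c4cc(OC)c(OC)c(OC)c4)cc3N)C2)cc1O`) gives 2130 nM and compound 2 (`COc1cc(C2=NOC(COc3ccc(-c4nnnn4-c4cc(OC)c(OC)c(OC)c4)cc3N)C2)ccc1O`) gives 2010 nM in the same test, so compound 2 stands level with compound 1 within the usual scatter. Compound 3 (`COc1cc(-n2nnnc2-c2ccc(OCC3CC(c4ccc(OC)c(OC)c4OC)=NO3)c(N)c2)cc(OC)c1OC`) keeps the shared core, but 2,3,4-trimethoxyphenyl replaces 4-hydroxy-3-methoxyphenyl on a carbon with a double bond to nitrogen (2,3,4-trimethoxyphenyl in place of 4-hydroxy-3-methoxyphenyl on a carbon with a double bond to nitrogen) in a single exchange. Within the data shown here, the only measured step at this place is a 1.1-fold lower number from compound 1 to compound 2 (0.03 log units; within the scatter) and it lies within the scatter. Among the measured compounds shown here, that step only rearranges the same two groups on the ring, and no measured compound lacks the hydroxy group there, so the evidence is thin. For the measured compounds named here, with that small step as the only guide, no step beyond the scatter is expected in this assay for this exchange, though a move in either direction remains possible. The expected size is a 1.0-fold lower number from compound 2 to compound 3 (0.00 log units; within the scatter) on this estimate. For compound 3 the estimated value is 2000 nM with a deliberately wide expected range of 600 nM to 6500 nM around it.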

Compound 3, half-maximal inhibitory concentration: 2030 nM
The estimate for compound 3 lay 1.0-fold (0.01 log units) below the measured number; the measured number falls inside the stated range.
By their numbers in this assay, from the lowest: compounds 2, 3 and 1 (each within the scatter of the next).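

In this assay, 2,3,4-trimethoxyphenyl in place of 4-hydroxy-3-methoxyphenyl gives a 1.0-fold higher number from compound 2 to compound 3 (0.00 log units; within the scatter), and the same group in place of 3-hydroxy-4-methoxyphenyl gives a 1.0-fold lower number from compound 1 to compound 3 (0.02 log units; within the scatter); both steps lie within the scatter. Within the data shown here, the earlier pair only moved the same two groups around the ring, whereas compound 3 is the first here with no hydroxy group on this ring, going from 1 hydrogen-bond donor to 0, and its number stays level with the other two, so at this position a hydroxy group is not required to hold the number at this level. Nothing measured here offers a reason for this flat result.

From the compounds shown here alone, all three compounds carry a phenyl ring with methoxy groups at this position, so a plain phenyl ring, a chlorophenyl ring or a phenyl ring bearing a carboxylic acid remains open. Going by these compounds, it also remains open whether any exchange at this position can produce a step beyond the scatter in this assay, in either direction.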